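The source may hold more compounds than are shown below. What is called first, only, known or untested is meant among the compounds shown, and "the series" means these compounds.

Compound 1 `O=C(COc1ccc(C(=O)/C=C/c2ccccc2Cl)cc1)N[C@H]1CCOC1=O`: 3240 nM
Compound 2 `O=C(COc1ccc(C(=O)/C=C/c2ccc(Br)cc2)cc1)N[C@H]1CCOC1=O`: 51700 nM
Compound 3 `O=C(COc1ccc(C(=O)/C=C/c2cccc(F)c2)cc1)N[C@H]1CCOC1=O`: 17200 nM

Of the compounds shown here, three sharing one core have been tested in a functional assay on DU-145 cells (Homo sapiens) for antiproliferative activity, read by MTT assay, with a stated time of 72 h; on this read-out higher numbers stand for weaker inhibition and lower numbers for stronger inhibition. Compound 3 gives the second highest of the three numbers: the gap a 5.3-fold higher number from compound 1 to compound 3 (0.72 log units; beyond the scatter) places it well behind compound 1, while the step of a 3.0-fold lower number from compound 2 to compound 3 (0.48 log units; beyond the scatter) places it ahead of compound 2. The step of a 16-fold higher number from compound 1 to compound 2 (1.20 log units; beyond the scatter) shows that exchanging the halogen on the phenyl ring can move the numbers a long way.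

Compound 4 `O=C(COc1ccc(C(=O)/C=C/c2cccc([N+](=O)[O-])c2)cc1)N[C@H]1CCOC1=O` differs from compound 3 by nitro in place of fluoro on an aromatic carbon. For the measured compounds named here, no measured pair exchanges a fluoro for a nitro, so the three steps bear on it only indirectly: they show that substituents on this ring matter, but not which way a nitro will pull. The expectation is therefore a step of a 1.4-fold lower number from compound 3 to compound 4 (0.16 log units; within the scatter) of small size, with a wide band around it. Compound 4 is estimated at 12000 nM in this assay, within 3000 nM to 50000 nM.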

Compound 4, half-maximal inhibitory concentration: 41800 nM
Beside the measured number, compound 4's estimate is 3.5-fold (0.54 log units) below it; low and high end bracket the measured number.
By their numbers in this assay, from the lowest: compound 1; then compound 3; then compounds 4 and 2 (each within the scatter of the next).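

In this assay, for the compounds shown here, the exchange of fluoro for nitro at this ring place gives a 2.4-fold higher number from compound 3 to compound 4 (0.39 log units; beyond the scatter) and so weakens inhibition, which fixes a direction for this change that the earlier steps could not give. The step of a 1.2-fold lower number from compound 2 to compound 4 (0.09 log units; within the scatter) leaves compound 4 level with compound 2 even though the two carry different groups at different ring places, while the step of a 13-fold higher number from compound 1 to compound 4 (1.11 log units; beyond the scatter) shows that the 3-nitrophenyl compound, like the others, stays well behind the 2-chlorophenyl compound. Nothing available explains these differences.

Going by these compounds alone, each group here appears at only one ring place, so the effect of the group cannot be separated from the effect of its place. On these data alone, whether an amine or a methoxy group at this same place would come closer to compound 1 also remains open.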